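This account rests on a few compounds, and the source may have more. Where it says the series, first, only, none or still open, it means among the compounds named here.

Measured compounds in a functional assay on HT-29 cells (Homo sapiens) for cytotoxicity, read by MTT assay, with a stated time of 72 h; on this read-out lower numbers stand for stronger inhibition and higher numbers for weaker inhibition:
Compound 1 `CCC/C(=C\B1OC(C)(C)C(C)(C)O1)C(O)(c1ccccc1)C1CC1` gives 83900 nM.
Compound 2 `CCC/C(=C\B1OC(C)(C)C(C)(C)O1)C1(O)CCCc2ccccc21` gives 86800 nM.
Compound 3 `CCCCCCC(C)(O)/C(=C/B1OC(C)(C)C(C)(C)O1)CCC` gives 57200 nM.

All three numbers sit close together. Compound 3 has the lowest of the three, yet its gaps to compound 1 and to compound 2 both lie within the usual scatter of this assay, so nothing separates them. Compound 4, `CCCCC(C)(O)/C(=C/B1OC(C)(C)C(C)(C)O1)CCC`, differs from compound 3 in one place: hydrogen in place of ethyl on a saturated chain carbon, five bonds along the chain from a double-bonded chain carbon and an oxygen on a saturated carbon. Among the measured compounds shown here, no measured pair shows what such a shortening of the chain does here, so the expectation rests on the change alone; a small step, or none beyond the scatter, in either direction, seems the likeliest outcome. Compound 4 is therefore estimated at 70000 nM, with a range from 30000 nM to 160000 nM. The expected step of a 1.2-fold higher number from compound 3 to compound 4 (0.09 log units; within the scatter) is accordingly modest.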

Compound 4, half-maximal inhibitory concentration: 69600 nM
Compound 4: the middle estimate sits 1.0-fold (0.00 log units) above what was measured; measured number inside the range.
By their numbers in this assay, from the lowest: compounds 3, 4, 1 and 2 (each within the scatter of the next).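

Hydrogen in place of ethyl at this saturated chain carbon gives a 1.2-fold higher number from compound 3 to compound 4 (0.09 log units; within the scatter) in this assay. Among the compounds shown here, this is the first direct comparison of two compounds differing in one place, and it shows that removing the ethyl leaves the two compounds indistinguishable on this read-out. No supporting measurement bears on this result. As far as these compounds go, whether a longer chain, an amine or a carboxylic acid at this place would give a clearly different number stays open. So does whether the same change would behave alike on the other compounds' cores.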